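A few compounds are considered here, and "the series" means these few. Any claim that something is new, unique, unknown or untested is made for them only; others in the source may bear on it.

In a functional assay on NCI-H2122 cells (Homo sapiens) for inhibition, read by microscopy, with a stated time of 10 days (on this read-out higher numbers stand for weaker inhibition and lower numbers for stronger inhibition), compound 1 `Cn1nc(-c2ccccc2)c2c1OC(N)=C(C#N)C2c1ccccc1` reaches only the limit of the assay, > 10000 nM, which is a boundary rather than a measured number. Its close relative compound 2 `Cn1nc(-c2ccccc2)c2c1OC(N)=C(C#N)C2c1ccc(C#N)cc1` gives 5200 nM in this assay, the only true number among the two results shown for this series. Going by the values given here, the single measured step, an at least 1.9-fold lower number from compound 1 to compound 2 (0.28 log units; that floor lies within the scatter), is bounded by the limit of > 10000 nM in this assay, at which 1 of the 2 values shown sits, and that floor sits within the usual scatter of repeated runs, so the true size of the step is not pinned down. Compound 3 `Cn1nc(-c2ccccc2)c2c1OC(N)=C(C#N)C2c1ccncc1` differs from compound 2 in one place: pyridin-4-yl in place of 4-cyanophenyl on a saturated ring carbon. The change takes away the cyano group that set compound 2 apart from compound 1 and replaces the whole aryl group with pyridin-4-yl. Among the compounds with values here, the only step on record bears on the presence of that cyano group and was not clearly larger than the scatter, so the reverse change is expected to shift the number only modestly, if at all, with a slight lean toward weaker inhibition. Compound 3 is therefore estimated at 7000 nM in this assay, with a plausible range from 2500 nM to 20000 nM. That estimate corresponds to a step of a 1.3-fold higher number from compound 2 to compound 3 (0.13 log units; within the scatter).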

Compound 3, half-maximal inhibitory concentration: 5200 nM
The estimate for compound 3 lay 1.3-fold (0.13 log units) above the measured number; the range from low to high includes it.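

In this assay, replacing 4-cyanophenyl with pyridin-4-yl on the saturated ring carbon gives no change at the digits printed from compound 2 to compound 3 (within the scatter), so two different aromatic rings at this position print the same number, and the cyano group is not required for that number. Compared with the plain phenyl group of compound 1, pyridin-4-yl gives an at least 1.9-fold lower number from compound 1 to compound 3 (0.28 log units; that floor lies within the scatter), a reading that matches the earlier step to compound 2 and is still not shown to exceed the scatter. Whether either group truly improves on phenyl cannot be settled because compound 1 has only a limit of the assay rather than a measured number: the limit of > 10000 nM in this assay, at which 1 of the 3 values shown sits.

The compounds shown leave open whether the same number would hold with the ring nitrogen placed as in pyridin-3-yl, or with a carboxylic acid or a methoxy group in place of the cyano group on the phenyl ring. They also leave open whether this position needs an aromatic ring at all, a question that a group such as cyclohexyl or a longer alkyl chain would address.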